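Fluoro placement and microsomal stability in the pyridyl series

The source may hold more compounds than are shown below. What is called first, only, known or untested is meant among the compounds shown, and "the series" means these compounds.

Going by the values given here, compound 2 `CCn1c(=O)/c(=C2\Sc3ccccc3N2C)s/c1=C\c1ccncc1` shows the lowest of the three numbers so far in an ADME assay on microsomes from liver (Mus musculus) for metabolic stability, with a stated time of 30 min (on this read-out lower numbers stand for a less stable compound and higher numbers for a more stable compound), where compound 2 gives 6%. Compound 1 `CCn1c(=O)/c(=C2\Sc3c(F)cccc3N2C)s/c1=C\c1ccccn1` is nearest, giving 12% in this assay, a gap that lies within the scatter. Compound 3 `CCn1c(=O)/c(=C2\Sc3cccc(F)c3N2C)s/c1=C\c1ccncc1` is furthest, giving 33% in this assay. Among the compounds with values here, the only single-point step among the measured compounds is a number 27 percentage points higher from compound 2 to compound 3 (beyond the scatter). Compound 4 `CCn1c(=O)/c(=C2\Sc3c(F)cccc3N2C)s/c1=C\c1ccncc1` is not yet measured. It differs from compound 2 in one place: fluoro in place of hydrogen on an aromatic carbon. Within the data shown here, the position is ortho to a fused ring, meta to a fused ring, the same aromatic position that carries fluoro in compound 1, though compound 1 and compound 4 differ also in the pyridyl attachment and no step between them is given. The step from compound 2 to compound 3 bears on the change in kind, fluoro for hydrogen, but not in position; it was a modest rise beyond the scatter. Compound 1, with fluoro at the position in question, shows 12%, within the scatter of compound 2. Taken together, the expected step is a number 9 percentage points higher from compound 2 to compound 4 (within the scatter), small and likely within the scatter, with a rise like that seen for compound 3 left open. Compound 4 is therefore estimated at 15% in this assay, with a range of 5% to 35%.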

Compound 4, percent of the compound remaining: 30%
Estimate against measurement, compound 4: 15 percentage points below; the range from low to high includes it.
By their numbers in this assay, from the lowest: compounds 2 and 1 (each within the scatter of the next); then compounds 4 and 3 (each within the scatter of the next).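

Fluoro in place of hydrogen at this aromatic carbon, ortho to a fused ring and meta to a fused ring, gives a number 24 percentage points higher from compound 2 to compound 4 (beyond the scatter) in this assay and so registers beyond the scatter when the pyridin-4-yl group is present. Compound 3 gives 33% and compound 4 gives 30% in this assay and these values lie within the scatter of each other, so among the compounds shown, the number reached with pyridin-4-yl does not separate the two fluoro placements. With fluoro held at this position, pyridin-4-yl in place of pyridin-2-yl gives a number 18 percentage points higher from compound 1 to compound 4 (beyond the scatter) and shows that the number here depends on the pyridyl attachment as well as on the fluoro. Nothing available explains either step.

On these data alone, whether the rise is particular to fluoro stays open, since no other group, such as chloro, methoxy or nitrile, appears at this carbon. Also open, as far as these compounds go, is how two fluoro groups on the same ring, one at each of the positions seen in compound 3 and compound 4, would read in this assay.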